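A Benzamide in Place of a Thiazolyl Amide

The source may hold more compounds than are shown below. What is called first, only, known or untested is meant among the compounds shown, and "the series" means these compounds.

Compound 1 `Cc1nc(C(=O)Nc2ccc(Cl)c(-c3nnc4c(Cl)cccn34)c2)cs1` bears a 2-methyl-1,3-thiazol-4-yl group on the carbonyl carbon of its amide. In a functional assay on MDA-MB-468 cells (Homo sapiens) for antiproliferative activity, read by MTT assay, with a stated time of 72 h (a higher number here means a weaker inhibitor, a lower number a stronger inhibitor), compound 1 gives only a limit, > 100000 nM. Compound 2 `O=C(Nc1ccc(Cl)c(-c2nnc3c(Cl)cccn23)c1)c1c(F)cccc1Cl` carries 2-chloro-6-fluorophenyl on that carbonyl carbon instead, and in this assay compound 2 gives 57600 nM. The step of an at least 1.7-fold lower number from compound 1 to compound 2 (0.23 log units; that floor lies within the scatter) is the only measured one that touches this carbonyl carbon, and its floor rests on the limit (the limit of > 100000 nM in this assay, at which 1 of the 2 values shown sits). Compound 3 `O=C(Nc1ccc(Cl)c(-c2nnc3c(Cl)cccn23)c1)c1ccccc1` differs from compound 1 by phenyl in place of 2-methyl-1,3-thiazol-4-yl on a carbonyl carbon. For the measured compounds named here, with the single measured step at this site staying within the scatter, compound 3 is expected to move no further than the scatter in this assay, an expected step of an at least 1.4-fold lower number from compound 1 to compound 3 (0.15 log units; that floor lies within the scatter). Compound 3 is therefore estimated at 70000 nM, with a range from 30000 nM to 200000 nM.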

Compound 3, half-maximal inhibitory concentration: > 100000 nM
Compound 3 gave a limit, no number; the forecaster's own chance of this, stated with the estimate: 40%; middle value at least 1.4-fold (0.15 log units) from the limit.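

Compound 3 gives only a limit in this assay, > 100000 nM, so phenyl on this carbonyl carbon yields no number, just as 2-methyl-1,3-thiazol-4-yl did in compound 1, and the step between those two compounds cannot be read. Of the three groups shown at this site, only 2-chloro-6-fluorophenyl in compound 2 gives a number. The one readable new step is an at least 1.7-fold higher number from compound 2 to compound 3 (0.23 log units; that floor lies within the scatter), and it is only a floor resting on a limit: the limit of > 100000 nM in this assay, at which 2 of the 3 values shown sit.

The compounds shown leave open whether a phenyl bearing only chlorine or only fluorine would give a number in this assay. They also leave open whether an amine such as piperidine, a carboxylic acid or a longer alkyl chain on this carbonyl carbon would move the value beyond the scatter.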